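Benzyl-type variants of the series: from compound 3 to compound 4

The source may hold more compounds than are shown below. What is called first, only, known or untested is meant among the compounds shown, and "the series" means these compounds.

Values in a functional assay on HOS cells (Homo sapiens) for inhibition, with a stated time of 72 h (a higher number here means a weaker inhibitor, a lower number a stronger inhibitor), so far:
compound 1 `NC1CCC(Nc2nc(NCc3ccc(Br)cc3)c3ncn(C4CCCC4)c3n2)CC1` gives 995 nM
compound 2 `NC1CCC(Nc2nc(NCc3ccc(-c4ccsc4)cc3)c3ncn(C4CCCC4)c3n2)CC1` gives 120 nM
compound 3 `NC1CCC(Nc2nc(NCc3ccc(-c4ccco4)nc3)c3ncn(C4CCCC4)c3n2)CC1` gives 44 nM

Compound 3 has the lowest number of the three. The measured steps are a 2.7-fold lower number from compound 2 to compound 3 (0.44 log units; beyond the scatter) and a 23-fold lower number from compound 1 to compound 3 (1.35 log units; beyond the scatter), and an 8.3-fold lower number from compound 1 to compound 2 (0.92 log units; beyond the scatter). Both compounds with two linked aromatic rings therefore sit lower than compound 1, and none of the three goes against this.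

Compound 4 `NC1CCC(Nc2nc(NCc3cc(Cl)ccc3O)c3ncn(C4CCCC4)c3n2)CC1` is still unmeasured. Its change is 5-chloro-2-hydroxyphenyl in place of 6-(furan-2-yl)pyridin-3-yl on a saturated chain carbon bound to a nitrogen on an aromatic ring, with 5-chloro-2-hydroxyphenyl in place of 6-(furan-2-yl)pyridin-3-yl on a saturated chain carbon bound to a nitrogen on an aromatic ring. Among the measured compounds shown here, no measured compound carries this group, so the reading is indirect. Like the 4-bromophenyl of compound 1, it has one aromatic ring and a halogen, so the closest guide is a 23-fold lower number from compound 1 to compound 3 (1.35 log units; beyond the scatter), read in reverse.

A large step to a higher number in this assay is expected, and the estimated step is a 16-fold higher number from compound 3 to compound 4 (1.20 log units; beyond the scatter). The expected value for compound 4 is 700 nM, with an estimated range of 200 nM to 2400 nM.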

Compound 4, half-maximal inhibitory concentration: 490 nM
For compound 4 the middle estimate is 1.4-fold (0.15 log units) above the measured one; low and high end bracket the measured number.
By their numbers in this assay, from the lowest: compound 3; then compound 2; then compound 4; then compound 1.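

In this assay there is a 2.0-fold lower number from compound 1 to compound 4 (0.31 log units; beyond the scatter) with 5-chloro-2-hydroxyphenyl in place of 4-bromophenyl, so groups with one aromatic ring and a halogen do not all give the same number at this position. The single ring still does not reach the two linked aromatic rings, with a 4.1-fold higher number from compound 2 to compound 4 (0.61 log units; beyond the scatter) and an 11-fold higher number from compound 3 to compound 4 (1.05 log units; beyond the scatter) in the same direction, and none of the four compounds goes against this. No supporting data bear on the reason for these differences.

Because the entering group differs from 4-bromophenyl in both its halogen and its hydroxy group, the compounds shown cannot assign the step to either one. Open too, from the compounds shown here alone, is whether a methoxy group or an amine in place of that hydroxy group would give a similar number on this ring.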